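Thiophen-3-yl for furan-2-yl on the pyridine series

A few compounds are considered here, and "the series" means these few. Any claim that something is new, unique, unknown or untested is made for them only; others in the source may bear on it.

Compound 1 `NC1CCC(Nc2nc(NCc3ccc(-c4ccsc4)cc3)c3ncn(C4CCCC4)c3n2)CC1` gives 315 nM
Compound 2 `NC1CCC(Nc2nc(NCc3ccc(-c4ccco4)nc3)c3ncn(C4CCCC4)c3n2)CC1` gives 86 nM

In a functional assay on HCT-116 cells (Homo sapiens) for inhibition, with a stated time of 72 h (a lower number here means a stronger inhibitor, a higher number a weaker inhibitor), compound 2 stands lowest of the two, at 86 nM. Compound 3 `NC1CCC(Nc2nc(NCc3ccc(-c4ccsc4)nc3)c3ncn(C4CCCC4)c3n2)CC1` has thiophen-3-yl in place of furan-2-yl on an aromatic carbon. Going by the values given here, one measured step bears on this: a 3.7-fold lower number from compound 1 to compound 2 (0.56 log units; beyond the scatter). That step changes both aromatic rings at once, so it cannot isolate the five-membered ring. Compound 3 shares thiophen-3-yl with compound 1, so a smaller rise is expected, a 1.6-fold higher number from compound 2 to compound 3 (0.21 log units; within the scatter). For compound 3 the estimated value is 140 nM, with an expected range of 55 nM to 320 nM.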

Compound 3, half-maximal inhibitory concentration: 145 nM
Beside the measured number, compound 3's estimate is 1.0-fold (0.02 log units) below it; low and high end bracket the measured number.
By their numbers in this assay, from the lowest: compounds 2 and 3 (each within the scatter of the next); then compound 1.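

In this assay the swap of the five-membered ring reads as a 1.7-fold higher number from compound 2 to compound 3 (0.23 log units; within the scatter) and leaves furan-2-yl and thiophen-3-yl not told apart on this ring. With thiophen-3-yl held fixed, 6-(thiophen-3-yl)pyridin-3-yl in place of 4-(thiophen-3-yl)phenyl gives a 2.2-fold lower number from compound 1 to compound 3 (0.34 log units; beyond the scatter) and so isolates the change of the six-membered ring, which the earlier double change could not do. No supporting data explain either step. From the compounds shown here alone, what an amine or a longer chain would do in place of the five-membered ring stays open.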